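Side-chain variation at the saturated ring position

This account rests on a few compounds, and the source may have more. Where it says the series, first, only, none or still open, it means among the compounds named here.

Compound 1 `Cn1ncc(Cl)c1-c1cc(C(=O)N[C@@H]2CN[C@H](CCO)C[C@H]2c2ccc(F)c(F)c2)oc1Cl` gives 360 nM in a functional assay on HCT-116 cells (Homo sapiens) for antiproliferative activity, read by sulforhodamine B assay, with a stated time of 72 h; a lower number here means a stronger inhibitor, a higher number a weaker inhibitor.
Compound 2 `C=CC[C@@H]1C[C@@H](c2ccc(Cl)c(Cl)c2)[C@H](NC(=O)c2cc(-c3c(Cl)cnn3C)c(Cl)o2)CN1` gives 780 nM.
Compound 3 `CNC(=O)C[C@@H]1C[C@@H](c2ccc(F)c(F)c2)[C@H](NC(=O)c2cc(-c3c(Cl)cnn3C)c(Cl)o2)CN1` gives 1100 nM.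

Compound 2 stands second highest of the three numbers in this assay; its gap to compound 3 lies within the scatter, while compound 1 lies beyond it, with the lower number. Among the measured compounds shown here, compound 4 `Cn1ncc(Cl)c1-c1cc(C(=O)N[C@@H]2CN[C@H](CC(=O)NCCO)C[C@H]2c2ccc(Cl)c(Cl)c2)oc1Cl` differs from compound 2 at a single place. (2-hydroxyethyl)carbamoyl in place of vinyl on a saturated chain carbon bound to a saturated ring carbon The only measured step at this place is a 3.1-fold higher number from compound 1 to compound 3 (0.49 log units; beyond the scatter), a modest move towards the higher number when methylcarbamoyl replaced hydroxymethyl. The entering (2-hydroxyethyl)carbamoyl combines both features of that step, so a step of comparable, perhaps smaller, size in the same direction is expected, a 1.7-fold higher number from compound 2 to compound 4 (0.22 log units; within the scatter). Compound 4 is therefore estimated at 1300 nM, with a range from 500 nM to 3500 nM.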

Compound 4, half-maximal inhibitory concentration: 670 nM
Compound 4: the middle estimate sits 1.9-fold (0.29 log units) above what was measured; the measured number falls inside the stated range.
By their numbers in this assay, from the lowest: compounds 1, 4, 2 and 3 (each within the scatter of the next, the first and the last beyond it).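

In this assay the exchange of vinyl for (2-hydroxyethyl)carbamoyl reads as a 1.2-fold lower number from compound 2 to compound 4 (0.07 log units; within the scatter), so this position accepts the larger chain without a readable shift. Among the compounds shown here, this differs from the only earlier step at this place, a 3.1-fold higher number from compound 1 to compound 3 (0.49 log units; beyond the scatter), which involved a different exchange. Nothing available explains this result.

On these data alone, it remains open how an amine, a carboxylic acid or a longer chain would read at this place, and whether (2-hydroxyethyl)carbamoyl would read the same on the core of compound 1.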